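This account rests on a few compounds, and the source may have more. Where it says the series, first, only, none or still open, it means among the compounds named here.

Working notes on the series. Compound 1 `CCC1(Cc2ccccc2)OS(=O)(=O)C=C1OCC(=O)OC` and compound 2 `CCC1(Cc2ccccc2)OS(=O)(=O)C=C1OCC1CCCCC1` share the same core and differ only in the group on a saturated chain carbon bound to an oxygen on an unsaturated carbon. In an ADME assay on HEL cells (Homo sapiens) for cytotoxicity, with a stated time of 3 days (a higher number here means that more compound is tolerated, a lower number that less compound is tolerated), compound 1 gives only a limit, > 400000 nM. In this assay compound 2 likewise gives only a limit, >= 200000 nM. Within the data shown here, the one measured step, a step that the two limits leave unreadable from compound 1 to compound 2, therefore cannot be sized: both values sit at limits, the limit of > 400000 nM in this assay, at which 1 of the 2 values shown sits, and (the limit of >= 200000 nM in this assay, at which 1 of the 2 values shown sits), and the two limits overlap. Among the measured compounds shown here, compound 2 thus stands at a limit, with the only other value shown also a limit, so no ordering within the pair can be read.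

Compound 3 `C=CCOC1=CS(=O)(=O)OC1(CC)Cc1ccccc1` is the next member. It differs from compound 2 by vinyl in place of cyclohexyl on a saturated chain carbon bound to an oxygen on an unsaturated carbon. For the measured compounds named here, the only step that bears on this change is the unreadable one from compound 1 to compound 2, so no step of a readable size is available, and nothing in the pair points to a change beyond the scatter in this assay. Compound 3 is accordingly expected to sit at or near the limits of this assay, estimated at 300000 nM within 100000 nM to 900000 nM. The expected step is a step that the limit leaves unreadable from compound 2 to compound 3.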

Compound 3, minimum cytotoxic concentration: 80000 nM
Compound 3: the middle estimate sits 3.8-fold (0.57 log units) above what was measured; measured number below the stated range.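

Among these compounds, compound 3 gives the first value in this assay that is not a limit, and it shows that this position, on a saturated chain carbon bound to an oxygen on an unsaturated carbon, can move the read-out beyond the scatter: vinyl in place of cyclohexyl gives an at least 2.5-fold lower number from compound 2 to compound 3 (0.39 log units; beyond the scatter), and vinyl in place of methoxycarbonyl gives an at least 5.0-fold lower number from compound 1 to compound 3 (0.69 log units; beyond the scatter). Both steps run towards less compound tolerated, and each gives only a smallest size, because the value of compound 1 is a limit: the limit of > 400000 nM in this assay, at which 1 of the 3 values shown sits. The same holds for the step that starts from compound 2, because its value is also a limit: the limit of >= 200000 nM in this assay, at which 1 of the 3 values shown sits.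

The change from cyclohexyl to vinyl alters both the ring and the double bond, so the compounds shown leave open which of the two goes with the lower number; a propyl chain, which has neither, or a longer chain ending in a double bond would separate them. Going by these compounds, the step from compound 1 to compound 2 cannot be read, so the order of those two stays open, as does the effect of an amine or a carboxylic acid at this position.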